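Bromo to tert-butyl: from compound 3 to compound 4

The source may report more compounds than this note shows. Statements on the series, on what has been measured and on what is new or still open speak of the compounds shown alone.

In a functional assay on SK-OV-3 cells (Homo sapiens) for antiproliferative activity, read by MTT assay, with a stated time of 72 h (on this read-out higher numbers stand for weaker inhibition and lower numbers for stronger inhibition), compound 1 `CC(C)(C)NC(=O)CCc1cccc2c1B(O)OC2` gives > 100000 nM, which is a limit of the assay. Compound 2 `O=C(CCc1cccc2c1B(O)OC2)Nc1ccc(F)cc1` gives 720 nM. Compound 3 `O=C(CCc1cccc2c1B(O)OC2)Nc1ccc(Br)cc1` gives 9200 nM, the higher of the two actual numbers. Compound 4 `CC(C)(C)c1ccc(NC(=O)CCc2cccc3c2B(O)OC3)cc1` carries tert-butyl in place of bromo on an aromatic carbon. Among the compounds with values here, the nearest precedent is a 13-fold higher number from compound 2 to compound 3 (1.11 log units; beyond the scatter), a large step beyond the scatter at the same aromatic carbon. The steps of an at least 130-fold lower number from compound 1 to compound 2 (2.14 log units; beyond the scatter) and an at least 10-fold lower number from compound 1 to compound 3 (1.03 log units; beyond the scatter) concern the amide-type nitrogen and bear only indirectly. On that single precedent, a further moderate rise in the number is expected. The expected step is a 2.0-fold higher number from compound 3 to compound 4 (0.29 log units; within the scatter). The estimated value for compound 4 is 18000 nM, expected within 4000 nM to 80000 nM.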

Compound 4, half-maximal inhibitory concentration: 4200 nM
Compound 4: the middle estimate sits 4.3-fold (0.63 log units) above what was measured; low and high end bracket the measured number.
By their numbers in this assay, from the lowest: compound 2; then compound 4; then compound 3. At a limit, above all of these: compound 1.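

In this assay, the change from bromo to tert-butyl gives a 2.2-fold lower number from compound 3 to compound 4 (0.34 log units; beyond the scatter), so the direction of the earlier fluoro-to-bromo rise does not continue at this aromatic carbon. Fluoro still gives the lowest number of the three aromatic substituents, with a 5.8-fold higher number from compound 2 to compound 4 (0.77 log units; beyond the scatter), and compound 3 stands against any steady rise with the size of the group. Nothing shown gives a reason for this reversal.

From the compounds shown here alone, whether an amine or a carboxylic acid on this aromatic carbon would give a number nearer to that of compound 2 or of compound 3 remains open.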